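The source may report more compounds than this note shows. Statements on the series, on what has been measured and on what is new or still open speak of the compounds shown alone.

Compound 1 `CCC/N=C(/NC#N)NCCCCn1nc(-c2ccccc2)ccc1=O`: 26.3%
Compound 2 `C=CCNC(=S)NCCCCn1nc(-c2ccccc2)ccc1=O`: 27.1%

In a functional assay on the whole organism with Rattus norvegicus as the target, at a dose of 100 mg/kg (a higher number here means more inhibition at the dose given (going by the name of the read-out), a lower number less inhibition), compound 2 and compound 1 lie within the scatter of each other, so neither stands apart. Compound 3 `N#CNC(=N)NCCCCn1nc(-c2ccccc2)ccc1=O` is the next compound. The change from compound 2 to compound 3: a group of 5 heavy atoms (2 carbon, 3 nitrogen; no ring) in place of a group of 6 heavy atoms (4 carbon, 1 nitrogen, 1 sulfur; no ring), on an amine nitrogen. For the measured compounds named here, one measured step bears on it, a number 0.8 percentage points higher from compound 1 to compound 2 (within the scatter): that step also exchanged the group on the same amine nitrogen and moved nothing beyond the scatter. For compound 3 the expected step is therefore a number 1.1 percentage points lower from compound 2 to compound 3 (within the scatter), nothing beyond the scatter. The estimate for compound 3 in this assay is 26%, within 14% to 38%.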

Compound 3, a percentage reported as inhibition, in the whole organism at one dose (the size of the read-out at that dose, not a potency): 61.2%
The estimate for compound 3 lay 35.2 percentage points below the measured number; measured number outside the range, above it.
By their numbers in this assay, from the lowest: compounds 1 and 2 (each within the scatter of the next); then compound 3.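

The exchange on the amine nitrogen, which had moved nothing beyond the scatter before, now matters in this assay: the result is a number 34.1 percentage points higher from compound 2 to compound 3 (beyond the scatter), and likewise a number 34.9 percentage points higher from compound 1 to compound 3 (beyond the scatter). Compound 3 keeps the nitrile of compound 1 but lacks its propyl chain, so the group at this place can change the read-out substantially. Nothing measured here explains the rise. As far as these compounds go, whether a methyl or ethyl group in place of the propyl chain would retain the higher number remains open. So does how a urea would compare at this place.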